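Swapping a Cyclohexyl Ring for a Cyclic Sulfone

The source may hold more compounds than are shown below. What is called first, only, known or untested is meant among the compounds shown, and "the series" means these compounds.

Three compounds were measured in a functional assay on cells for antagonist activity at C-X-C chemokine receptor type 4 (Homo sapiens), read by fluorescence and calcium flux, with stated times of 25 min and 90 s; on this read-out lower numbers stand for stronger inhibition and higher numbers for weaker inhibition:
Compound 1, `c1cncc(CN(CCCCN(C[C@H]2Cc3ccccc3CN2)[C@H]2CCCc3cccnc32)Cc2cccnc2)c1`, gave 471 nM.
Compound 2, `c1ccc2c(c1)CN[C@@H](CN(CCCCN(Cc1ccncc1)Cc1ccncc1)[C@H]1CCCc3cccnc31)C2`, gave 832 nM.
Compound 3, `c1ccc2c(c1)CN[C@@H](CN(CCCCNCC1CCCCC1)[C@H]1CCCc3cccnc31)C2`, gave 158 nM.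

Compound 3 has the lowest number of the three; compound 1 sits nearest, with a higher number that lies beyond the usual scatter, and compound 2 sits furthest, also beyond it. Compound 4, `O=S1(=O)CCC(CNCCCCN(C[C@H]2Cc3ccccc3CN2)[C@H]2CCCc3cccnc32)CC1`, differs from compound 3 in one place: 1,1-dioxothian-4-yl in place of cyclohexyl on a saturated chain carbon bound to an amine nitrogen. Going by the values given here, no measured pair shows this change, so its size is open. With nothing in the data to anchor it, a modest weakening is expected for compound 4 in this assay, with a step of a 2.0-fold higher number from compound 3 to compound 4 (0.31 log units; beyond the scatter). Compound 4 is therefore estimated at 320 nM, within a range from 110 nM to 950 nM.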

Compound 4, half-maximal inhibitory concentration: 17 nM
Beside the measured number, compound 4's estimate is 19-fold (1.27 log units) above it; the whole stated range lies above it.
By their numbers in this assay, from the lowest: compound 4; then compound 3; then compounds 1 and 2 (each within the scatter of the next).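

In this assay, 1,1-dioxothian-4-yl in place of cyclohexyl on a saturated chain carbon bound to an amine nitrogen gives a 9.3-fold lower number from compound 3 to compound 4 (0.97 log units; beyond the scatter). Going by these compounds alone, this is the first reading of this position, and it shows that the ring at the chain end can be changed with a gain rather than a loss. The entering ring counts two hydrogen-bond acceptors where cyclohexyl counts none, but no available measurement connects the gain to them or to any other feature of the group.

Going by these compounds, how a tetrahydropyran or piperidine ring would compare at this position remains open.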